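Methyl to hydrogen on the aryl ether oxygen

The source may hold more compounds than are shown below. What is called first, only, known or untested is meant among the compounds shown, and "the series" means these compounds.

Two pyrazole compounds bearing a cyanomethyl substituent have been measured so far. Compound 1 `COc1cc(C)cc(-c2c(-c3ccnc(-c4ccc(N(C)C)cc4)c3)cnn2CC#N)c1` gives 49% in a functional assay on Malme-3M cells (Homo sapiens) for cytotoxicity, read by sulforhodamine B assay, with a stated time of 48 h, tested at 100 nM; a lower number here means a stronger effect, a higher number a weaker effect of the compound at the concentration tested. Compound 2 `COc1cc(C)cc(-c2nn(CC#N)cc2-c2ccnc(-c3ccc(N(C)C)cc3)c2)c1` gives 46% in this assay, the lowest of the two numbers, though the gap to its nearest neighbour, compound 1, sits within the scatter of repeated measurements, so the two values cannot be ordered against each other.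

Compound 3 `Cc1cc(O)cc(-c2nn(CC#N)cc2-c2ccnc(-c3ccc(N(C)C)cc3)c2)c1` has not yet been measured in this assay. It differs from compound 2 in one place: hydrogen in place of methyl on an oxygen on an aromatic ring. Cut one bond further out, the same change reads methoxy to hydroxy, so the 3-methoxy-5-methylphenyl group of compound 2 becomes a 3-hydroxy-5-methylphenyl group in compound 3.

Within the data shown here, no measured pair shows this change, so its size is unknown here. On the two values in hand the expectation for compound 3 is a step of a number 4 percentage points higher from compound 2 to compound 3 (within the scatter), which is not expected to reach beyond the scatter in either direction. Compound 3 is therefore estimated at 50% in this assay, with a range from 30% to 72%.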

Compound 3, a percentage reported as activity, at one concentration (the size of the read-out at that concentration, not a potency): 94%
Compound 3: the middle estimate sits 44 percentage points below what was measured; the whole stated range lies below it.
By their numbers in this assay, from the lowest: compounds 2 and 1 (each within the scatter of the next); then compound 3.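

In this assay, replacing methoxy with hydroxy on the 3-methoxy-5-methylphenyl group gives a number 48 percentage points higher from compound 2 to compound 3 (beyond the scatter), so the effect of compound 2 at the concentration tested is largely lost with this single change. Compound 1 and compound 2 both carry the methoxy group and could not show this, but the new result shows that the methyl on this oxygen is not a neutral detail and that the substituent there strongly influences the read-out. Nothing available here explains why removing this one methyl has so large an effect.

The compounds shown do not reveal whether the methyl itself matters or the free hydroxy is what weakens the effect: an ethoxy group or a longer alkoxy chain on the same oxygen, or an amine or a fluorine in place of the hydroxy, could help separate these readings. From the compounds shown here alone, it also remains open whether the same change would give a step of similar size on compound 1, whose core differs from that of compound 2.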